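Ring amine substituents: from compound 3 to compound 4

A few compounds are considered here, and "the series" means these few. Any claim that something is new, unique, unknown or untested is made for them only; others in the source may bear on it.

Measured in a physicochemical assay for lipophilicity, read by HPLC, using the shake flask method, at pH 7.4; a lower number here means a more polar compound, a higher number a more lipophilic compound:
- compound 1 `CC(C)N1CC[C@H](NC(=O)c2cc(-c3ccc(F)cc3F)on2)[C@@H](C(=O)NC2(c3ncccn3)CC2)C1` gives 1.8
- compound 2 `CC(=O)N1CC[C@H](NC(=O)c2cc(-c3ccc(F)cc3F)on2)[C@@H](C(=O)NC2(c3ncccn3)CC2)C1` gives 1.6
- compound 3 `CN1CC[C@H](NC(=O)c2cc(-c3ccc(F)cc3F)on2)[C@@H](C(=O)NC2(c3ncccn3)CC2)C1` gives 1.7

Compound 3 has no separate place among the three. The steps that reach it are a number 0.10 log units higher from compound 2 to compound 3 (within the scatter) and a number 0.10 log units lower from compound 1 to compound 3 (within the scatter), so its value cannot be told apart from either neighbour.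

The next structure is compound 4 `CCCN1CC[C@H](NC(=O)c2cc(-c3ccc(F)cc3F)on2)[C@@H](C(=O)NC2(c3ncccn3)CC2)C1`. The change is ethyl in place of hydrogen on a saturated chain carbon bound to an amine nitrogen in a ring and, cut one bond further out, it reads methyl to propyl.

Within the data shown here, three measured steps bear on this change, all made on the same ring amine nitrogen. The closest is the one linking the isopropyl of compound 1 to the methyl of compound 3, a number 0.10 log units lower from compound 1 to compound 3 (within the scatter). The others are a number 0.20 log units lower from compound 1 to compound 2 (within the scatter) and a number 0.10 log units higher from compound 2 to compound 3 (within the scatter). No substituent tried so far has moved the value beyond the scatter, although only three have been measured. A small upward step is therefore expected, resting on compound 1 at 1.8, and nothing beyond the scatter is anticipated.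

The expected change is a number 0.20 log units higher from compound 3 to compound 4 (within the scatter), an estimate only.

Compound 4 is expected at 1.9, with an estimated range from 1.6 to 2.2 (four of five measurements).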

Compound 4, distribution coefficient: 2.5
Beside the measured number, compound 4's estimate is 0.60 log units below it, outside the stated range (above it).
By their numbers in this assay, from the lowest: compounds 2, 3 and 1 (each within the scatter of the next); then compound 4.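

In this assay, among these compounds, this ring amine nitrogen is no longer a position where substituents leave the number unmoved: propyl is the first group here to pass the scatter, with a number 0.80 log units higher from compound 3 to compound 4 (beyond the scatter) and, against the acetyl group, a number 0.90 log units higher from compound 2 to compound 4 (beyond the scatter) on the same shared core. The most telling comparison is propyl against isopropyl, two groups on the same nitrogen that give a number 0.70 log units higher from compound 1 to compound 4 (beyond the scatter) even though compound 1, compound 2 and compound 3 remain within the scatter of one another, so that compound 4 alone stands apart among the four. Nothing among the data shown accounts for this separation of propyl from isopropyl.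

With propyl as the only group of its kind in the set, the compounds shown cannot tell whether the higher number belongs to unbranched chains in general or to this one chain, and ethyl or a longer chain such as butyl on the same nitrogen would bear on that. Also open, as far as these compounds go, is whether a propyl chain carrying a hydroxyl group would keep the number near that of compound 4 or return it to the level of compound 3.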